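Hydroxy in place of ethyl on a quinoline-urea scaffold

The source may report more compounds than this note shows. Statements on the series, on what has been measured and on what is new or still open speak of the compounds shown alone.

Measured compounds:
compound 1, `CCc1ccc(NC(=O)Nc2cc(C)nc3ccccc23)cc1`: 3300 nM
compound 2, `Cc1cc(NC(=O)Nc2cccc(C(N)=O)c2)c2ccccc2n1`: 100 nM
compound 3, `Cc1cc(NC(=O)Nc2ccccc2C(C)(C)C)c2ccccc2n1`: 100 nM

Of the compounds shown here, three sharing one core have been measured in a physicochemical assay for solubility, at pH 7.4; on this read-out lower numbers stand for lower solubility and higher numbers for higher solubility. Compound 1 holds the highest number of the three; compound 2 and compound 3 each give a value far lower than compound 1, and the two of them sit at the same value. Compound 4, `Cc1cc(NC(=O)Nc2ccc(O)cc2)c2ccccc2n1`, has not yet been measured. It arises from compound 1 by one change, (hydroxy in place of ethyl on an aromatic carbon), on an aromatic carbon of a six-membered aromatic ring of carbon only, para to a large group. Among the measured compounds shown here, with no measured pair showing this exact change, the expected step is modest and upward: the expected step is a 1.8-fold higher number from compound 1 to compound 4 (0.26 log units; within the scatter), judged from compound 1 at 3300 nM as the starting point. Compound 4 is therefore estimated at 6000 nM, within 1500 nM to 25000 nM.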

Compound 4, solubility: 100 nM
Compound 4: the middle estimate sits 60-fold (1.78 log units) above what was measured, outside the stated range (below it).
By their numbers in this assay, from the lowest: compounds 2, 3 and 4 (each within the scatter of the next); then compound 1.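

Among the compounds shown here, on an aromatic carbon para to a large group, hydroxy in place of ethyl gives a 33-fold lower number from compound 1 to compound 4 (1.52 log units; beyond the scatter) in this assay and is the first single-place change available in this set. It shows that the read-out at this position is sensitive to the group it carries, and that this one exchange is enough to produce a large step. Nothing measured here accounts for the step. Going by these compounds, it remains open whether the fall belongs to hydroxy itself or to the loss of ethyl. A methoxy group, an amine or a longer chain on this carbon could separate those two readings.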